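Solubility notes on the pyridazin-3-yl step

The compounds below may be only part of what the source reports. "The series", "measured", "known", "first", "only" and "open" are said of these compounds alone.

- compound 1 `N#CCC(=O)NC1=NN(c2ccc(Cl)c(Cl)c2)CC1` with 202000 nM measured
- compound 2 `O=C(NC1=NN(c2ccc(Cl)c(Cl)c2)CC1)c1ccccn1` with 11000 nM measured

Both values come from a physicochemical assay for solubility, measured as kinetic solubility, with a stated time of 1 h, at pH 7.4 (a higher number here means a more soluble compound, a lower number a less soluble compound), and compound 2 is the lower of the two. Among the measured compounds shown here, the only measured step is an 18-fold lower number from compound 1 to compound 2 (1.26 log units; beyond the scatter) and it is the one bearing on the next change.

Compound 3 `O=C(NC1=NN(c2ccc(Cl)c(Cl)c2)CC1)c1cccnn1` keeps the shared core and carries pyridazin-3-yl in place of pyridin-2-yl on a carbonyl carbon in full.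

The measured step sits on a carbonyl carbon too, but it exchanged cyanomethyl for pyridin-2-yl, whereas here one six-membered aromatic ring replaces another. Its size serves only as an upper guide. For the measured compounds named here, no measured step exchanges one aromatic ring for another, so the direction rests on the structural change alone and is held loosely. In this assay a modest rise is expected, possibly not beyond the scatter.

For compound 3 the estimate is 22000 nM with an expected range of 8000 nM to 70000 nM in this read-out. The expected change is a 2.0-fold higher number from compound 2 to compound 3 (0.30 log units; within the scatter) on this estimate.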

Compound 3, solubility: 67000 nM
Compound 3: middle estimate off by 3.0-fold (0.48 log units), on the low side, within the range that was stated.
By their numbers in this assay, from the lowest: compound 2; then compound 3; then compound 1.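

In this assay, the exchange of one six-membered aromatic ring for another on the carbonyl carbon is enough on its own to move the number, giving a 6.1-fold higher number from compound 2 to compound 3 (0.78 log units; beyond the scatter) at the same count of 6 heavy atoms and no net charge. An aromatic ring at this place therefore does not fix the read-out at the level of compound 2, and the pair shows that the ring's hetero atoms matter to the number: pyridazin-3-yl has 2 where pyridin-2-yl has 1. Cyanomethyl still stands apart from the new ring, with a 3.0-fold lower number from compound 1 to compound 3 (0.48 log units; beyond the scatter), and nothing measured in this set speaks to the reason for either step.

Open, as far as these compounds go, is whether a pyrimidin-2-yl or pyrazin-2-yl ring on the same carbonyl carbon would sit with compound 3 or with compound 2, so two aromatic rings with different hetero atom counts cannot yet be read as a trend. Also open, from the compounds shown here alone, is how an amine or a carboxylic acid on such a ring would read in this assay, and whether the ordering of these three groups holds on any core other than the shared one.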